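Hydroxy in place of ethyl on the chain of compound 3

The source may report more compounds than this note shows. Statements on the series, on what has been measured and on what is new or still open speak of the compounds shown alone.

Measured compounds:
compound 1 `CC(C)c1ccc2nc(N)sc2c1`: > 10 mg/kg in a functional assay on the whole organism with Rattus norvegicus as the target (a higher number here means that more compound is needed for the effect, a lower number that less compound is needed), a limit of the assay
compound 2 `Nc1nc2ccc(C(F)(F)C(F)(F)F)cc2s1`: 2.5 mg/kg
compound 3 `CCCCn1c(=N)sc2cc(OC(F)(F)F)ccc21`: 10 mg/kg

Compound 1 sits at the limit of > 10 mg/kg in this assay, at which 1 of the 3 values shown sits. Of the two numbers in this assay, compound 3 has the higher one and compound 2 the lower, a gap beyond the scatter. Whether the pentafluoroethyl of compound 2 or its unsubstituted amine is behind this cannot be told from two compounds.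

Compound 4 `N=c1sc2cc(OC(F)(F)F)ccc2n1CCO` differs from compound 3 by hydroxy in place of ethyl on a saturated chain carbon, two bonds along the chain from an aromatic nitrogen. Among the compounds with values here, no step between measured compounds touches this chain, so the direction rests on expectation alone. The step from compound 3 to compound 4 in this assay is expected to be small, a 1.5-fold higher number from compound 3 to compound 4 (0.18 log units; within the scatter), probably toward a higher number, and it may well fall within the scatter. Compound 4 is therefore estimated at 15 mg/kg, with a range from 5 mg/kg to 50 mg/kg, and a fair chance that only a limit is reported, as for compound 1.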

Compound 4, dose for half-maximal effect: 8 mg/kg
The estimate for compound 4 lay 1.9-fold (0.27 log units) above the measured number, and the stated range covers the measured number.
By their numbers in this assay, from the lowest: compound 2; then compounds 4 and 3 (each within the scatter of the next).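

In this assay, hydroxy in place of ethyl at this place, read one bond further out as butyl to 2-hydroxyethyl, gives a 1.3-fold lower number from compound 3 to compound 4 (0.10 log units; within the scatter). Within the data shown here, this is the first step read on this chain, and it shows that the number stays within the scatter although the chain gets shorter by one heavy atom and gains a hydrogen-bond donor and a hydrogen-bond acceptor. Nothing at hand bears on why the number holds across this change.

Open, as far as these compounds go, is whether an amine or a carboxylic acid in place of the hydroxy, or a longer chain carrying the same hydroxy, would also stay within the scatter of these two compounds. A single pair also leaves open whether this change reads the same on a core carrying the pentafluoroethyl of compound 2.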